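Swapping thiophen-2-yl for pyridin-2-yl on a shared core

The source may hold more compounds than are shown below. What is called first, only, known or untested is meant among the compounds shown, and "the series" means these compounds.

Measured compounds:
compound 1 `Oc1ccc(-c2cc(-c3ccccn3)nc(-c3ccccc3Cl)c2)cc1`, an assay on isolated protein for inhibition of DNA topoisomerase 1 (Homo sapiens), with a stated time of 30 min, tested at 100 uM; a higher number here means a stronger effect of the compound at the concentration tested, a lower number a weaker effect: 5.2%
compound 2 `Oc1cccc(-c2cc(-c3ccc(Cl)cc3)nc(-c3ccccn3)c2)c1`, this assay: 30%
compound 3 `Oc1cccc(-c2cc(-c3cccs3)nc(-c3ccccc3Cl)c2)c1`, this assay: 2.7%

Among these three numbers, compound 3 gives the lowest reading in this assay. Its gap to compound 1 lies within the usual scatter of repeated measurements, so nothing separates the two; only compound 2 stands clearly apart, with a number beyond the scatter above compound 3.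

Compound 4 `Oc1cccc(-c2cc(-c3ccccn3)nc(-c3ccccc3Cl)c2)c1` has not yet been measured in this assay. It differs from compound 3 in one place:
pyridin-2-yl in place of thiophen-2-yl on an aromatic carbon
Compound 4 shares with compound 1 both the pyridin-2-yl and the 2-chlorophenyl group, and compound 1 sits with compound 3 at the low end of the readings. On that basis the step of a number 3.3 percentage points higher from compound 3 to compound 4 (within the scatter) is expected to stay within the scatter, perhaps a slight rise. Compound 4 is therefore estimated at 6%, between 0% and 20%.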

Compound 4, a percentage reported as inhibition, at one concentration (the size of the read-out at that concentration, not a potency): 0%
Beside the measured number, compound 4's estimate is 6 percentage points above it, and the stated range covers the measured number.
By their numbers in this assay, from the lowest: compounds 4, 3 and 1 (each within the scatter of the next); then compound 2.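

In this assay, pyridin-2-yl in place of thiophen-2-yl on this aromatic carbon (a number 2.7 percentage points lower from compound 3 to compound 4 (within the scatter)) leaves the two compounds inseparable, with the 2-chlorophenyl and 3-hydroxyphenyl groups held constant. The step of 3-hydroxyphenyl in place of 4-hydroxyphenyl (a number 5.2 percentage points lower from compound 1 to compound 4 (within the scatter)) separates nothing either, whereas 2-chlorophenyl in place of 4-chlorophenyl (a number 30 percentage points lower from compound 2 to compound 4 (beyond the scatter)) is the only one of the three beyond the scatter. Nothing at hand bears on the cause of these readings.

From the compounds shown here alone, whether an amine or a carboxylic acid at this position would lift the reading remains open. So does whether thiophen-2-yl and pyridin-2-yl would also read alike alongside 4-chlorophenyl.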